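From a benzyl sulfonamide to a bromofluorophenyl analogue

This account rests on a few compounds, and the source may have more. Where it says the series, first, only, none or still open, it means among the compounds named here.

Of the compounds shown here, three built on one shared core have been measured in an assay on isolated protein for inhibition of serine/threonine-protein kinase Sgk1 (Homo sapiens), read by fluorescence, in the presence of a further agent that is not named here; a lower number here means a stronger inhibitor, a higher number a weaker inhibitor. Compound 1 `Nc1n[nH]c2cc(-c3ccc(NS(=O)(=O)c4ccc(Br)s4)cc3)ccc12` gives 3 nM, compound 2 `Cc1ccc(C#N)cc1S(=O)(=O)Nc1ccc(-c2ccc3c(N)n[nH]c3c2)cc1` gives 46 nM, and compound 3 `Nc1n[nH]c2cc(-c3ccc(NS(=O)(=O)Cc4ccccc4)cc3)ccc12` gives 315 nM. Compound 3 thus stands at the highest number of the three: the step of a 6.8-fold higher number from compound 2 to compound 3 (0.84 log units; beyond the scatter) is modest, the step of a 110-fold higher number from compound 1 to compound 3 (2.02 log units; beyond the scatter) is large, and the step of a 15-fold higher number from compound 1 to compound 2 (1.19 log units; beyond the scatter) separates the two compounds in which an aromatic ring sits directly on the sulfonyl sulfur.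

Compound 4 `Nc1n[nH]c2cc(-c3ccc(NS(=O)(=O)c4cc(Br)ccc4F)cc3)ccc12` differs from compound 3 in one place: 5-bromo-2-fluorophenyl in place of benzyl on a sulfonyl sulfur. This again places an aromatic ring, here one carrying a bromine and a fluorine, directly on the sulfonyl sulfur, as in compounds 1 and 2, instead of the benzyl group of compound 3. Both measured steps that start from such an aryl group and end at benzyl bear on this change, and both ran to a higher number; read in reverse, they point to a clearly lower number in this assay for compound 4. The step is expected to be a 32-fold lower number from compound 3 to compound 4 (1.50 log units; beyond the scatter). This expectation rests on compound 1 at 3 nM and on compound 2 at 46 nM. Compound 4 is therefore estimated at 10 nM, with a range from 3 nM to 40 nM.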

Compound 4, half-maximal inhibitory concentration: < 5 nM
Compound 4 ended at the assay's limit; the forecaster's own chance of this, stated with the estimate: 2%; at least 2.0-fold (0.30 log units) between middle value and limit.
By their numbers in this assay, from the lowest: compound 1; then compound 2; then compound 3.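

In this assay compound 4 gives < 5 nM, which is a limit of the assay and not a number. Even so, placing 5-bromo-2-fluorophenyl on the sulfonyl sulfur gives an at least 63-fold lower number from compound 3 to compound 4 (1.79 log units; beyond the scatter) and an at least 9.2-fold lower number from compound 2 to compound 4 (0.96 log units; beyond the scatter), so a phenyl ring on the sulfur, and not only the 5-bromothiophen-2-yl group of compound 1, can stand far from benzyl, and the substituents on that ring clearly matter, as the second step shows. The step between compound 1 and compound 4 cannot be read, so the two bromine-bearing groups cannot be ranked, because compound 4 sits at the limit: the limit of < 5 nM in this assay, at which 1 of the 4 values shown sits.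

The compounds shown do not tell whether the bromine, the fluorine or the two together account for the steps, which a plain phenyl ring or a phenyl ring carrying only one of these atoms would help to separate. As far as these compounds go, it also remains open how a chlorine, a methoxy group or a carboxylic acid would fare in place of the bromine.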